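Pyridin-4-yl in place of pyridin-3-yl: compound 3 expected

This account rests on a few compounds, and the source may have more. Where it says the series, first, only, none or still open, it means among the compounds named here.

Compound 2 `COc1ccc(C(=O)/C=C/c2cn(-c3ccccc3)nc2-c2cccnc2)c(OC)c1` carries a 2,4-dimethoxyphenyl on its carbonyl carbon and in a functional assay on MCF7 cells (Homo sapiens) for inhibition, read by sulforhodamine B assay, with a stated time of 72 h (a higher number here means a weaker inhibitor, a lower number a stronger inhibitor), gives 2300 nM. Of the two numbers measured, compound 2 has the lowest, its nearest neighbour being compound 1 `O=C(/C=C/c1cn(-c2ccccc2)nc1-c1cccnc1)c1ccccn1`, which in this assay gives 4200 nM. That step, a 1.8-fold lower number from compound 1 to compound 2 (0.26 log units; within the scatter), lies within the scatter. Compound 3 `COc1ccc(C(=O)/C=C/c2cn(-c3ccccc3)nc2-c2ccncc2)c(OC)c1` differs from compound 2 in one place: pyridin-4-yl in place of pyridin-3-yl on an aromatic carbon. For the measured compounds named here, no measured step touches this position, as the only recorded step concerns the carbonyl substituent, so no shift beyond the scatter is expected. Compound 3 is therefore estimated at 2300 nM, between 1000 nM and 5500 nM, an expected step of no change at the digits printed from compound 2 to compound 3 (within the scatter).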

Compound 3, half-maximal inhibitory concentration: 8800 nM
Beside the measured number, compound 3's estimate is 3.8-fold (0.58 log units) below it; measured number outside the range, above it.
By their numbers in this assay, from the lowest: compounds 2 and 1 (each within the scatter of the next); then compound 3.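

For the compounds shown here, on the shared core, this aromatic carbon is the first position where a change moves the number beyond the scatter in this assay. The same atoms joined differently, with pyridin-4-yl in place of pyridin-3-yl, give a 3.8-fold higher number from compound 2 to compound 3 (0.58 log units; beyond the scatter), whereas the change on the carbonyl carbon between compound 1 and compound 2 stayed within the scatter. Nothing available explains this shift. Still open, from the compounds shown here alone, is how a plain phenyl or an aminophenyl would compare at this position. Also open, going by these compounds, is whether the same step would appear with pyridin-2-yl on the carbonyl carbon.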